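Aryl swap on the piperidine of a dopamine receptor agonist

The compounds below may be only part of what the source reports. "The series", "measured", "known", "first", "only" and "open" are said of these compounds alone.

Measured compounds:
- compound 1 `Cc1cccc(NC(=O)CN2CCC(c3cccc(F)c3)CC2)c1`: 512 nM
- compound 2 `Cc1cccc(C(=O)NCN2CCC(c3ccccn3)CC2)c1`: 9 nM
- compound 3 `Cc1cccc(NC(=O)CN2CCC(c3ccc(O)cn3)CC2)c1`: 3.8 nM

In a functional assay on HEK293 cells for agonist activity at D(4) dopamine receptor (Homo sapiens), read by FLIPR (a lower number here means that less compound is needed, a higher number that more compound is needed for the effect), compound 2 stands second highest of the three numbers; compound 3 lies nearest to it and compound 1 furthest, both beyond the scatter. Compound 4 `COc1ccccc1C1CCN(CNC(=O)c2cccc(C)c2)CC1` has not been measured. It differs from compound 2 in one place: 2-methoxyphenyl in place of pyridin-2-yl on a saturated ring carbon. Among the measured compounds shown here, no measured step covers this exact exchange. The closest comparison is a 130-fold lower number from compound 1 to compound 3 (2.13 log units; beyond the scatter), where a pyridine-type ring bearing a hydroxyl replaced a carbon-only ring on the same saturated ring carbon and gave a large drop in the number. The step from compound 2 to compound 4 runs the other way, carbon-only ring in place of a pyridine ring, though on a different linker and with a methoxy group instead of a hydroxyl, so the size is uncertain. A higher number is therefore expected for compound 4, estimated at 100 nM, with a range from 20 nM to 600 nM. This estimate means a step of an 11-fold higher number from compound 2 to compound 4 (1.05 log units; beyond the scatter), expected to lie beyond the scatter.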

Compound 4, half-maximal effective concentration: 206 nM
Compound 4: middle estimate off by 2.1-fold (0.31 log units), on the low side, within the range that was stated.
By their numbers in this assay, from the lowest: compound 3; then compound 2; then compound 4; then compound 1.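

In this assay, the exchange on the saturated ring carbon gives a 23-fold higher number from compound 2 to compound 4 (1.36 log units; beyond the scatter), so this position responds strongly on the linker of compound 2 as well, and not only on that of compound 1 and compound 3. Unlike the earlier step, which brought in a hydroxyl, this one involves no hydrogen-bond donor, and the entering and leaving groups have the same hydrogen-bond acceptor count and no net charge, so these counts alone do not predict the size of the step. Nothing measured here offers an explanation for the step.

The step combines the loss of the pyridine ring nitrogen with the gain of the methoxy group, and the compounds shown do not separate the two. A plain phenyl group at this position, on the linker of compound 2, would be needed to tell them apart.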